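Working notes: from compound 2 to compound 3

This account rests on a few compounds, and the source may have more. Where it says the series, first, only, none or still open, it means among the compounds named here.

Measured so far:
Compound 1, `O=C(O)CCCO/N=c1/ccn([C@@H]2O[C@H](COP(=O)(O)OP(=O)(O)OP(=O)(O)O)[C@@H](O)[C@H]2O)c(=O)[nH]1`, in a functional assay on 1321-N1 cells for agonist activity at P2Y purinoceptor 6 (Homo sapiens), read by scintillation counting and inositol phosphate accumulation (a lower number here means that less compound is needed, a higher number that more compound is needed for the effect), gives 697 nM.
Compound 2, `O=c1[nH]/c(=N\OCCCc2ccc([N+](=O)[O-])cc2)ccn1[C@@H]1O[C@H](COP(=O)(O)OP(=O)(O)OP(=O)(O)O)[C@@H](O)[C@H]1O`, in this assay gives 1330 nM.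

Compound 2 stands within the scatter of compound 1; the step of a 1.9-fold higher number from compound 1 to compound 2 (0.28 log units; within the scatter) does not separate the two. Compound 3, `O=c1[nH]/c(=N\OCCCc2ccsc2)ccn1[C@@H]1O[C@H](COP(=O)(O)OP(=O)(O)OP(=O)(O)O)[C@@H](O)[C@H]1O`, differs from compound 2 by thiophen-3-yl in place of 4-nitrophenyl on a saturated chain carbon, three bonds along the chain from an oxygen. Among the measured compounds shown here, no measured step exchanges one aromatic group for another at this position; the only step there, a 1.9-fold higher number from compound 1 to compound 2 (0.28 log units; within the scatter), stays within the scatter. Nothing here supports a move beyond the scatter for compound 3 in this assay, so the expected step is a 1.1-fold lower number from compound 2 to compound 3 (0.04 log units; within the scatter). Compound 3 is estimated at 1200 nM, within a range of 450 nM to 3200 nM.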

Compound 3, half-maximal effective concentration: 164 nM
Beside the measured number, compound 3's estimate is 7.3-fold (0.86 log units) above it; the whole stated range lies above it.
By their numbers in this assay, from the lowest: compound 3; then compounds 1 and 2 (each within the scatter of the next).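

Among the compounds shown here, at this position the terminal group does make a difference in this assay: thiophen-3-yl in place of 4-nitrophenyl gives the first step beyond the scatter at this place (an 8.1-fold lower number from compound 2 to compound 3 (0.91 log units; beyond the scatter)). Thiophen-3-yl in place of carboxy also moves beyond the scatter (a 4.3-fold lower number from compound 1 to compound 3 (0.63 log units; beyond the scatter)), so it separates from both earlier groups, which did not separate from each other. Nothing available explains the change.

The step changes the ring and removes the nitro group together, so unsubstituted phenyl would be needed to separate the two. Thiophen-2-yl, furan-3-yl and a shorter or longer chain remain open.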